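This account rests on a few compounds, and the source may have more. Where it says the series, first, only, none or still open, it means among the compounds named here.

Measured so far:
- compound 1, `CN1CCN(c2ccc(Nc3nc(-c4cccc(NC(=O)c5ccccc5F)c4)sc3C(=O)O)cc2)CC1`: 86.9%
- compound 2, `CN1CCN(c2ccc(Nc3nc(-c4cccc(NC(=O)c5ccc(Cl)cc5)c4)sc3C(=O)O)cc2)CC1`: 90.9%
- compound 3, `CN1CCN(c2ccc(Nc3nc(-c4cccc(NC(=O)c5ccccc5F)c4)sc3C(N)=O)cc2)CC1`: 97.3%

All three share one core and were tested in a functional assay on Raji cells (Homo sapiens) for antiproliferative activity, read by CCK-8 assay, with a stated time of 72 h, tested at 40 uM; a higher number here means more inhibition at the concentration tested (going by the name of the read-out), a lower number less inhibition. Compound 1 and compound 2 differ only in the group attached to a carbonyl carbon (4-chlorophenyl in place of 2-fluorophenyl on a carbonyl carbon), and this gave a number 4 percentage points higher from compound 1 to compound 2 (within the scatter). Compound 1 and compound 3 differ at another carbonyl carbon (amino in place of hydroxy on a carbonyl carbon), and this gave a number 10.4 percentage points higher from compound 1 to compound 3 (beyond the scatter), so compound 3 stands highest of the three, although its gap to compound 2 lies within the scatter.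

Compound 4, `CN1CCN(c2ccc(Nc3nc(-c4cccc(NC(=O)c5ccc(Cl)cc5)c4)sc3C(N)=O)cc2)CC1`, has not been measured. It differs from compound 3 in the same way that compound 2 differs from compound 1 (4-chlorophenyl in place of 2-fluorophenyl on a carbonyl carbon); the surroundings of the place are the same in both pairs, so this is the same kind of change. Since that change gave a number 4 percentage points higher from compound 1 to compound 2 (within the scatter), a step of similar size is expected for compound 4, that is a number 0.2 percentage points higher from compound 3 to compound 4 (within the scatter), also because compound 3 already sits at 97.3% and there is little room above it. Compound 4 is therefore estimated at 97.5% in this assay.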

Compound 4, a percentage reported as inhibition, at one concentration (the size of the read-out at that concentration, not a potency): 92.6%
Compound 4: the middle estimate sits 4.9 percentage points above what was measured, and the stated range ends above it.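

On the amide-bearing core, putting 4-chlorophenyl in place of 2-fluorophenyl gave a number 4.7 percentage points lower from compound 3 to compound 4 (within the scatter), and putting amino in place of hydroxy on the core carbonyl carbon, with 4-chlorophenyl present, gave a number 1.7 percentage points higher from compound 2 to compound 4 (within the scatter). In this assay, the 4-chlorophenyl change cannot be told apart between the two cores, although its two steps point in opposite directions, so no consistent gain or loss can be claimed for it: the same change on two cores in this assay, a number 4 percentage points higher (within the scatter) from compound 1 to compound 2 and a number 4.7 percentage points lower (within the scatter) from compound 3 to compound 4, 8.7 percentage points apart, within the scatter of two such steps The amino change likewise shows no clear dependence on its surroundings, but a single pair on each side cannot prove that it carries over unchanged, only that any difference is too small to be seen here: the same change on two cores in this assay, a number 10.4 percentage points higher (beyond the scatter) from compound 1 to compound 3 and a number 1.7 percentage points higher (within the scatter) from compound 2 to compound 4, 8.7 percentage points apart, within the scatter of two such steps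

The compounds shown leave open how a plain phenyl or a cyclohexyl would behave on the amide carbonyl carbon, and how a methyl ester or a nitrile would compare with the carboxylic acid and the primary amide. They also leave open how these compounds would rank at lower concentrations.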